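The source may hold more compounds than are shown below. What is called first, only, known or untested is meant among the compounds shown, and "the series" means these compounds.

Measured so far:
Compound 1, `CO/N=C(\CCN1CCC(c2ccccn2)CC1)c1ccc(Cl)cc1`, gives 195 nM.
Compound 2, `O/N=C(\CCCN1CCN(c2ccccn2)CC1)c1ccc(F)cc1`, gives 9.5 nM.

Both values come from a functional assay on HEK293 cells with D(4) dopamine receptor (Homo sapiens) as the target, read by FLIPR; on this read-out lower numbers stand for an effect already at smaller amounts and higher numbers for an effect only at larger amounts of compound. Of the two numbers, compound 2 stands lowest; the value of compound 1 is the higher one, and the gap between them lies beyond the usual scatter.

Compound 3, `O/N=C(/CCCN1CCN(c2ccccn2)CC1)c1ccc(F)cc1`, has not yet been measured. It differs from compound 2 only in how one part of the molecule is drawn: the two compounds have the same atoms and bonds and differ only in configuration as drawn: 1 of 1 stereo elements differ; a double bond is drawn E in compound 2 and Z in compound 3. Among the compounds with values here, no measured pair shows what such a change alone does in this assay, so the size of the step cannot be read from the data. A modest rise is the expected outcome, but a step either way, or none beyond the scatter, remains possible. Compound 3 is therefore expected to give about 30 nM, with a range from 5 nM to 200 nM. The expected step is a 3.2-fold higher number from compound 2 to compound 3 (0.50 log units; beyond the scatter).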

Compound 3, half-maximal effective concentration: 59.3 nM
Compound 3: the middle estimate sits 2.0-fold (0.30 log units) below what was measured; measured number inside the range.
By their numbers in this assay, from the lowest: compound 2; then compound 3; then compound 1.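

In this assay, redrawing the double bond from E to Z gives a 6.2-fold higher number from compound 2 to compound 3 (0.80 log units; beyond the scatter), so the geometry at this one position matters even though no atom is added or removed. Compound 1 differs from compound 2 in several places at once, so the earlier numbers could not separate out an effect of geometry. Here the step can be assigned to the double bond alone because nothing else changes: the fact that compounds 2 and 3 differ only in the configuration as drawn

Why the E form gives the lower number remains open, as does whether the same preference holds in a compound with a different side chain or aryl group, since this is a single pair. It is also unknown how a longer chain between the double bond and the piperazine, or an ethoxy group in place of the hydroxyl on the double-bond nitrogen, would behave in either geometry.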